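The compounds below may be only part of what the source reports. "The series", "measured", "known", "first", "only" and "open" are said of these compounds alone.

Working notes on the series, read in a functional assay on HL-60 cells (Homo sapiens) for inhibition, read by MTT assay, with a stated time of 72 h; on this read-out higher numbers stand for weaker inhibition and lower numbers for stronger inhibition. For the measured compounds named here, compound 1 (`CC(=O)Nc1cccc(-c2nc(C)oc2C(=O)N2CCN(c3cccc(Cl)c3)CC2)c1`) gives 208 nM, the only number so far. Compound 2 (`COc1ccc(-c2nc(C)oc2C(=O)N2CCN(c3cccc(Cl)c3)CC2)cc1`) is reported as "not active" (no number reported), with no number attached. Compound 3 (`COc1ccc(-c2nc(C)oc2C(=O)N2CCN(c3cccc(Cl)c3)CC2)cc1O`) is also reported as "not active" (no number reported), so it has no place on a numeric scale and stands with compound 2 as the second entry without a number.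

The next step leads to compound 4 (`COc1cc(-c2nc(C)oc2C(=O)N2CCN(c3cccc(Cl)c3)CC2)ccc1O`). The change is 4-hydroxy-3-methoxyphenyl in place of 3-hydroxy-4-methoxyphenyl on an aromatic carbon, and the two have the same atoms, joined differently. The rest of the structure is unchanged.

Going by the values given here, no measured step shows what such a swap does, and compound 3 offers no number to step from, so the expectation rests on thin evidence. Both compounds carrying a methoxy-bearing phenyl group, compound 2 and compound 3, read "not active" (no number reported) in this assay. The expected step from compound 3 is therefore small, with no clear gain, and a report of no activity remains the likeliest outcome. If a number does appear, it is expected to be a weak one, on the higher side of the value of compound 1 at 208 nM. For compound 4 the estimated value is 3000 nM, with an expected range of 500 nM to 20000 nM.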

Compound 4, half-maximal inhibitory concentration: 85.9 nM
Beside the measured number, compound 4's estimate is 35-fold (1.54 log units) above it; measured number outside the range, below it.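

At this position, on an aromatic carbon next to the ring nitrogen, the exchange of 3-hydroxy-4-methoxyphenyl for 4-hydroxy-3-methoxyphenyl keeps the atoms the same yet separates compound 3, reported as not active in this assay, from compound 4, which gives a number; the arrangement of the two oxygen substituents on the phenyl group therefore matters here, and a methoxy-bearing phenyl group does not by itself mean a report of no activity. The position also tolerates more than 3-acetamidophenyl, since a 2.4-fold lower number from compound 1 to compound 4 (0.38 log units; beyond the scatter) is a modest change that lies beyond the usual scatter. The size of the change between compound 3 and compound 4 cannot be read, as compound 3 has no number to step from.

Nothing available here explains why the two arrangements differ. The compounds shown leave open whether the 4-hydroxy group, the 3-methoxy group or the pair is what matters, and how a 4-aminophenyl group, a 4-carboxyphenyl group or a 4-hydroxy-3-ethoxyphenyl group would read at this position.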